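The source may hold more compounds than are shown below. What is called first, only, known or untested is meant among the compounds shown, and "the series" means these compounds.

Measured compounds:

Compound 1, `Cc1cc(C)cc(NC(=O)COc2cc(C)nc3ccc(Cl)cc23)c1`, gives 8000 nM.
Compound 2, `Cc1cc(C)cc(NC(=O)COc2cc(C)nc3ccc(C)cc23)c1`, gives 83000 nM.
Compound 3, `COc1ccc2nc(C)cc(OCC(=O)Nc3cccc(C)c3)c2c1`, gives 193000 nM.

These values come from a physicochemical assay for solubility, in phosphate buffer, measured as kinetic solubility, with a stated time of 1 h, at pH 7.4; on this read-out higher numbers stand for higher solubility and lower numbers for lower solubility. Compound 3 stands highest of the three: compound 2 is nearest, and compound 1 furthest, both lower than compound 3 by more than the scatter. Going by the values given here, the only single-place step among the measured compounds is a 10-fold higher number from compound 1 to compound 2 (1.02 log units; beyond the scatter).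

Compound 4, `COc1ccc2nc(C)cc(OCC(=O)Nc3ccncn3)c2c1`, differs from compound 3 in one place: pyrimidin-4-yl in place of 3-methylphenyl on an amide-type nitrogen. Among the compounds with values here, no measured step shows this kind of exchange on an amide-type nitrogen; the one step in hand concerns a different part of the shared core, so it gives no direct guide. With nothing to anchor the direction, the expectation is a modest rise in this assay, a 1.6-fold higher number from compound 3 to compound 4 (0.19 log units; within the scatter), with wide uncertainty. Compound 4 is therefore estimated at 300000 nM, expected to lie between 100000 nM and 900000 nM.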

Compound 4, solubility: 27500 nM
Compound 4: middle estimate off by 11-fold (1.04 log units), on the high side, and the stated range ends above it.
By their numbers in this assay, from the lowest: compound 1; then compound 4; then compound 2; then compound 3.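

Going by these compounds alone, on an amide-type nitrogen, putting pyrimidin-4-yl in place of 3-methylphenyl gives a 7.0-fold lower number from compound 3 to compound 4 (0.85 log units; beyond the scatter) in this assay and is the first measured change at this position, with a step beyond the scatter. A ring of carbon only leaves here and a ring with 2 hetero atoms and 2 hydrogen-bond acceptors enters, so the group on this nitrogen moves the read-out, not only the part of the shared core changed in the earlier step. No measurement in hand says why the number falls.

Still open, on these data alone, is whether the fall goes with the two ring nitrogens or with the loss of the methyl. A plain phenyl or a pyridine ring on this nitrogen would help separate those two readings.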